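Dimethylthiophene-fused anilines: loss of one methoxy

The source may report more compounds than this note shows. Statements on the series, on what has been measured and on what is new or still open speak of the compounds shown alone.

Measured compounds and their inhibition values:
Compound 1, `Cc1sc2c(Nc3ccc(C#N)cc3)cccc2c1C`: 69%
Compound 2, `Cc1sc2c(Nc3cccnc3)cccc2c1C`: 70.9%
Compound 3, `COc1ccc(Nc2cccc3c(C)c(C)sc23)cc1OC`: 100%

In a functional assay for inhibition, with a stated time of 2 h, tested at 0.0625 g/L (on this read-out higher numbers stand for more inhibition at the one concentration tested (going by the name of the read-out) and lower numbers for less inhibition), compound 3 gives 100%, the highest of the three numbers. The nearest is compound 2, whose value in this assay is 70.9%, a gap that lies beyond the scatter; the furthest is compound 1, whose value in this assay is 69%, also beyond the scatter. Compound 3 thus stands clearly apart from both.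

Compound 4, `COc1ccc(Nc2cccc3c(C)c(C)sc23)cc1`, has not yet been measured. Compared with compound 3 it shows the following change: hydrogen in place of methoxy on an aromatic carbon

For the measured compounds named here, no measured pair shows this kind of change, so there is no step to lean on. The expectation is a decrease that may reach beyond the scatter, since compound 3 already sits at 100% and there is no room for a rise. For compound 4 in this assay the estimated value is 85%, within 62% to 100%. The step expected is a number 15 percentage points lower from compound 3 to compound 4 (beyond the scatter).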

Compound 4, a percentage reported as inhibition, at one concentration (the size of the read-out at that concentration, not a potency): 99.7%
For compound 4 the middle estimate is 14.7 percentage points below the measured one; the measured number falls inside the stated range.
By their numbers in this assay, from the lowest: compounds 1 and 2 (each within the scatter of the next); then compounds 4 and 3 (each within the scatter of the next).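

In this assay, hydrogen in place of methoxy, ortho to a methoxy group and meta to a large group, gives a number 0.3 percentage points lower from compound 3 to compound 4 (within the scatter), so the methoxy at this place can go without a measurable change at the one concentration tested, though with both values at the top of the read-out, a weaker effect at a lower concentration could stay hidden. Methoxy in place of cyano on an aromatic carbon gives a number 30.7 percentage points higher from compound 1 to compound 4 (beyond the scatter), a large step that shows the remaining methoxy position weighs far more in this read-out than the position just emptied. Nothing measured on hand explains either step.

Open, from the compounds shown here alone, is whether an amine, a carboxylic acid or an ethoxy group at the emptied place would hold the read-out. Also open, going by these compounds, is whether a ring carrying only hydrogen, with neither methoxy, would do so.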